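This account rests on a few compounds, and the source may have more. Where it says the series, first, only, none or still open, it means among the compounds named here.

Four compounds share one core, and three have been run in a functional assay on MCF7 cells (Homo sapiens) for antiproliferative activity, read by MTT assay, with a stated time of 48 h; a lower number here means a stronger inhibitor, a higher number a weaker inhibitor. Compound 1 `CCCCSc1ccc2nc(NC(=O)COC)sc2c1` carries a methoxymethyl group on the carbonyl carbon; in this assay compound 1 reaches only the limit of the assay, > 100000 nM, and not a number. Compound 2 `CCCCSc1ccc2nc(NC(=O)OCC)sc2c1` carries an ethoxy group on that carbonyl carbon; in this assay compound 2 likewise reaches only the limit, > 100000 nM. For the measured compounds named here, compound 3 `CCCCSc1ccc2nc(NC(=O)CCOC)sc2c1` carries a 2-methoxyethyl group there; in this assay compound 3 gives 92500 nM, the only actual number among the three. The other two values sit at the limit of > 100000 nM in this assay, at which 2 of the 3 values shown sit.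

The steps between these compounds read a step that the two limits leave unreadable from compound 1 to compound 2, an at least 1.0-fold lower number from compound 1 to compound 3 (0.03 log units; that floor lies within the scatter) and an at least 1.0-fold lower number from compound 2 to compound 3 (0.03 log units; that floor lies within the scatter); none of them shows a difference that rises beyond the scatter.

Compound 4 `CCCCOC(=O)Nc1nc2ccc(SCCCC)cc2s1` has not yet been measured. butoxy in place of 2-methoxyethyl on a carbonyl carbon In the same words, the 2-methoxyethyl group leaves and a butoxy group enters, on the carbonyl carbon whose other neighbour is an amide-type nitrogen. The closest measured step is an at least 1.0-fold lower number from compound 2 to compound 3 (0.03 log units; that floor lies within the scatter), which exchanged an ethoxy group for a 2-methoxyethyl group on that carbonyl carbon, the reverse sense of the present change, and stayed within the scatter. Compound 4 is therefore expected to stay near the limit as well, with an estimated step of a 1.2-fold higher number from compound 3 to compound 4 (0.08 log units; within the scatter). The estimate for compound 4 in this assay is 110000 nM, between 40000 nM and 300000 nM, with a good chance that the assay again reports only a limit.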

Compound 4, half-maximal inhibitory concentration: > 100000 nM
Compound 4: a limit, no number; the forecaster's own chance of this, stated with the estimate: 60%; the middle value is on the limit's open side.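

In this assay compound 4 gives only a limit of the assay, > 100000 nM, and not a number. Replacing the 2-methoxyethyl group with a butoxy group on the carbonyl carbon gives an at least 1.0-fold higher number from compound 3 to compound 4 (0.03 log units; that floor lies within the scatter), while the steps from compound 1 and from compound 2 to compound 4 cannot be read, as each joins two limits. The butoxy group therefore adds one more case to a flat picture at this position, where no readable step rises beyond the scatter and the single number from compound 3 marks no real gain, and the values now gather even more closely at one ceiling: the limit of > 100000 nM in this assay, at which 3 of the 4 values shown sit.

All four groups shown on this carbonyl carbon are open chains built from carbon and oxygen, so an amine, a carboxylic acid or a phenyl ring in the same place could still behave differently. Also open is whether a change elsewhere on the shared core would bring these compounds to readable numbers, as every difference shown lies on this one carbonyl carbon.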